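The source may report more compounds than this note shows. Statements on the series, on what has been measured and on what is new or still open speak of the compounds shown alone.

Measured compounds in an ADME assay on microsomes from liver (Mus musculus) for metabolic stability, read by LC-MS, using NADPH, with stated times of 5 min and 30 min, tested at 1 uM; a higher number here means faster removal of the compound, a lower number slower removal:
- compound 1 `CC(c1ccc2ncc(-c3cnn(C)c3)cc2c1)n1nnc2ncc(-c3ccc(C(N)=O)c(F)c3)nc21`: 30 uL/min
- compound 2 `CC(c1cc2cc(-c3cnn(C)c3)cnc2cc1F)n1nnc2ncc(-c3ccc(C(N)=O)c(F)c3)nc21`: 6 uL/min
- compound 3 `CNC(=O)c1ccc(-c2cnc3nnn(C(C)c4cc5cc(-c6cnn(C)c6)cnc5cc4F)c3n2)cc1F`: 24 uL/min

Compound 2 gives the lowest number of the three in this assay. Among the compounds with values here, the one single-point step that leads to it is a 5.0-fold lower number from compound 1 to compound 2 (0.70 log units; beyond the scatter), fluoro in place of hydrogen on an aromatic carbon; the step away from it is a 4.0-fold higher number from compound 2 to compound 3 (0.60 log units; beyond the scatter), methyl in place of hydrogen on an amide-type nitrogen. Both steps lie beyond the scatter, so compound 2 stands apart from compound 1 and from compound 3 by a modest margin.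

Compound 4 `CC(c1c(F)cc2ncc(-c3cnn(C)c3)cc2c1F)n1nnc2ncc(-c3ccc(C(N)=O)c(F)c3)nc21` differs from compound 2 by fluoro in place of hydrogen on an aromatic carbon. Within the data shown here, the step that bears on it is a 5.0-fold lower number from compound 1 to compound 2 (0.70 log units; beyond the scatter), the only fluoro-for-hydrogen change recorded, which gave a modest lowering. Among the measured compounds shown here, a second fluoro on the same ring has no precedent here, and compound 2 already sits at the low end, so a smaller step is expected, in the lowering direction or none beyond the scatter. The expected step is a 1.5-fold lower number from compound 2 to compound 4 (0.18 log units; within the scatter). Compound 4 is estimated at 4 uL/min, within 2 uL/min to 12 uL/min.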

Compound 4, intrinsic clearance in a liver preparation (reported as CLH), per the amount of preparation that the assay uses: 50 uL/min
Estimate against measurement, compound 4: 13-fold (1.10 log units) below; measured number outside the range, above it.
By their numbers in this assay, from the lowest: compound 2; then compounds 3, 1 and 4 (each within the scatter of the next, the first and the last beyond it).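

In this assay, fluoro in place of hydrogen on this ring does not act in one direction: a 5.0-fold lower number from compound 1 to compound 2 (0.70 log units; beyond the scatter), whereas an 8.3-fold higher number from compound 2 to compound 4 (0.92 log units; beyond the scatter), with both steps beyond the scatter and running opposite ways. The fluoro that enters here stands ortho to a large group, ortho to a fused ring and meta to the fluoro group already present, so the same change reverses its direction at this place in the presence of that first fluoro. Nothing available gives a reason for this reversal.

Going by these compounds, it remains open whether a fluoro at this place would give a higher number without the other fluoro group on the ring. Also open, on these data alone, is how a chloro or methoxy group at this same place would read.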